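This account rests on a few compounds, and the source may have more. Where it says the series, first, only, none or still open, it means among the compounds named here.

Working notes on the series. All three compounds share one core and differ only in the amine attached to the carbonyl of a short side arm. Compound 1 `CC(C)(C)c1ccc(C(=O)N2CCC3(CC2)C(=O)N(CC(=O)N2CCCC(O)C2)CN3c2ccccc2)cc1` carries a cyclic amine at that carbonyl, and in an assay on HEK293 cells for displacement of a labelled ligand from NPC1-like intracellular cholesterol transporter 1 (Homo sapiens) (a lower number here means a stronger inhibitor, a higher number a weaker inhibitor), compound 1 gives 12200 nM, which places it as a weak inhibitor. Among the measured compounds shown here, compound 2 `COC(=O)CCNC(=O)CN1CN(c2ccccc2)C2(CCN(C(=O)c3ccc(C(C)(C)C)cc3)CC2)C1=O` carries an open-chain ester amine at the same carbonyl; in this assay compound 2 gives "not determined" (no result reported), so compound 2 stands nowhere on the numbers, and no measured step connects it to compound 1. Compound 3 `CCOC(=O)C1CCCN(C(=O)CN2CN(c3ccccc3)C3(CCN(C(=O)c4ccc(C(C)(C)C)cc4)CC3)C2=O)C1` is the next point in the same position: 3-(ethoxycarbonyl)piperidin-1-yl in place of (2-(methoxycarbonyl)ethyl)amino on a carbonyl carbon. Both ends of this change keep an ester and the same amide carbonyl; the ring that enters is of the same size as the cyclic amine of compound 1. For the measured compounds named here, no measured step covers this change, so the direction cannot be read from a neighbour; the step in this assay is expected to be none beyond the scatter, with compound 3 expected to stay in the weak range that compound 1 shows at 12200 nM. In this assay compound 3 is estimated at 10000 nM, with a range of 3000 nM to 40000 nM.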

Compound 3, half-maximal inhibitory concentration: 8200 nM
Estimate against measurement, compound 3: 1.2-fold (0.09 log units) above; the range from low to high includes it.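

In this assay the position now has its first readable step, which is a 1.5-fold lower number from compound 1 to compound 3 (0.17 log units; within the scatter) with ethoxycarbonyl in place of hydroxy on a saturated ring carbon. On this pair, a ring ester and a ring alcohol on the same cyclic amine cannot be told apart, and the side arm tolerates the larger substituent without leaving the weak range. The steps that involve compound 2 cannot be read, so the exchange of (2-(methoxycarbonyl)ethyl)amino for 3-(ethoxycarbonyl)piperidin-1-yl on a carbonyl carbon has no measured size, and no data shown bear on why compound 1 and compound 3 read alike.

The compounds shown leave open whether any group at this carbonyl moves the number beyond the scatter, since only two readings exist and both are weak. A carboxylic acid or a primary amine on the same ring carbon, or a plain piperidin-1-yl without a substituent, would test whether that ring carbon matters at all.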